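Solubility notes: amide extension on the shared core

This account rests on a few compounds, and the source may have more. Where it says the series, first, only, none or still open, it means among the compounds named here.

Compound 1 `CNC(=O)c1cc(C(=O)N[C@H]2[C@@H]3COC[C@@H]32)cc2c1OC[C@@]2(CO)c1ccccc1` in a physicochemical assay for solubility (a higher number here means a more soluble compound, a lower number a less soluble compound), gives >= 202 ug/mL, which is a limit of the assay.
Compound 2 `CNC(=O)c1cc(C(=O)NC)c2c(c1)[C@H](c1ccccc1)CO2` in this assay gives >= 130 ug/mL, again a limit.
Compound 3 `CNC(=O)c1cc(C(=O)NC)c2c(c1)[C@H](c1ccccc1)[C@@H](CF)O2` in this assay gives >= 149 ug/mL, also a limit.

Compound 2 stands at the limit of >= 130 ug/mL in this assay, at which 1 of the 3 values shown sits, and the two further values shown are likewise limits, so compound 2 cannot be placed among them on a number. Among the compounds with values here, the single measured step, a step that the two limits leave unreadable from compound 2 to compound 3, lies between two limits and cannot be read.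

Compound 4 `CCC(=O)N1C[C@@H]2[C@H](C1)[C@H]2NC(=O)c1cc(C(=O)NC)c2c(c1)[C@H](c1ccccc1)CO2` differs from compound 2 by a group of 10 heavy atoms (8 carbon, 1 nitrogen, 1 oxygen; one three-membered non-aromatic ring of carbon only, one five-membered non-aromatic ring with 1 hetero atom) in place of one carbon atom, on an amide-type nitrogen. No measured step bears on this change: the only step shown concerns a fluoromethyl group at a different place and is unreadable in any case. No direction and no size can therefore be taken from the data; the estimate rests on nothing measured and is kept near the limit of compound 2, with a wide range.

Compound 4 is expected to give 70 ug/mL in this assay, estimated between 20 ug/mL and 200 ug/mL. The step this estimate means, an at least 1.8-fold lower number from compound 2 to compound 4 (0.26 log units; that floor lies within the scatter), is an expectation only.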

Compound 4, solubility: >= 163 ug/mL
Compound 4 ended at the assay's limit (the forecaster's own chance of this, stated with the estimate: 25%); at least 2.3-fold (0.36 log units) between middle value and limit.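

In this assay compound 4 gives >= 163 ug/mL, a limit of the assay. Compound 2 gives >= 130 ug/mL, also a limit, so the step between compound 2 and compound 4 cannot be read. The compounds shown leave open whether the larger group on the amide-type nitrogen of compound 4 changes solubility at all, in either direction.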